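From cyclopentyl to ethoxymethyl on the shared core

This account rests on a few compounds, and the source may have more. Where it says the series, first, only, none or still open, it means among the compounds named here.

Measured in an ADME assay on microsomes from liver (Rattus norvegicus) for metabolic stability, read by mass spectrometry, using NADPH, with a stated time of 10 min; on this read-out lower numbers stand for a less stable compound and higher numbers for a more stable compound:
Compound 1 `COc1cccc(OC)c1-c1c(C2CC2)[nH]c(=O)c(-c2nnc(Cc3ccc(Cl)cc3)o2)c1O`: 51%
Compound 2 `CCCCc1[nH]c(=O)c(-c2nnc(Cc3ccccc3Cl)o2)c(O)c1-c1c(OC)cccc1OC`: 24%
Compound 3 `COc1cccc(OC)c1-c1c(C2CCCC2)[nH]c(=O)c(-c2nnc(Cc3ccc(Cl)cc3)o2)c1O`: 66%

Compound 3 stands highest of the three, with the gaps to both others beyond the scatter. Compound 4 `CCOCc1[nH]c(=O)c(-c2nnc(Cc3ccc(Cl)cc3)o2)c(O)c1-c1c(OC)cccc1OC` has not yet been measured. It differs from compound 3 by ethoxymethyl in place of cyclopentyl on an aromatic carbon. Going by the values given here, the one measured step at this place, cyclopentyl in place of cyclopropyl, gave a number 15 percentage points higher from compound 1 to compound 3 (beyond the scatter). Compound 2 also has no ring there and gives 24%, though it differs in another place too. Among the compounds with values here, no measured compound carries ethoxymethyl. A moderate fall in this assay is therefore expected, and the expected step is a number 21 percentage points lower from compound 3 to compound 4 (beyond the scatter). For compound 4 the estimate is 45%, with an expected range from 22% to 66%.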

Compound 4, percent of the compound remaining: 74%
Beside the measured number, compound 4's estimate is 29 percentage points below it; the whole stated range lies below it.
By their numbers in this assay, from the lowest: compound 2; then compound 1; then compounds 3 and 4 (each within the scatter of the next).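

At this position, a ring is not required to keep the number high in this assay: the open ethoxymethyl chain replaces cyclopentyl with a number 8 percentage points higher from compound 3 to compound 4 (within the scatter) and no loss beyond the scatter. Replacing cyclopropyl with the same chain gives a number 23 percentage points higher from compound 1 to compound 4 (beyond the scatter) on the shared core, so this position accepts a chain carrying an oxygen as well as the larger ring. Nothing available explains this result.

Going by these compounds, whether the oxygen itself matters remains open, since no all-carbon chain is comparable in one place. On these data alone, how an amine or a carboxylic acid at this position would read in this assay also remains open.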